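The source may hold more compounds than are shown below. What is called first, only, known or untested is meant among the compounds shown, and "the series" means these compounds.

Compound 1, `O=S(=O)(/C=C/c1ccc(F)cc1)Cc1ccc(Nc2ncnc3ccccc23)cc1`, in a functional assay on NCI-H520 cells (Homo sapiens) (a lower number here means a stronger inhibitor of growth, a higher number a weaker inhibitor of growth), gives 13000 nM. Compound 2, `O=S(=O)(/C=C/c1ccc(Br)cc1)Cc1ccc(Nc2ncnc3ccccc23)cc1`, differs from it by bromo in place of fluoro on an aromatic carbon. For compound 2 this assay reports only a limit, > 100000 nM. The step from the one to the other is an at least 7.6-fold higher number from compound 1 to compound 2 (0.88 log units; beyond the scatter), and its size is bounded because of the limit of > 100000 nM in this assay, at which 2 of the 3 values shown sit.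

Compound 3, `COc1cc2ncnc(Nc3ccc(CS(=O)(=O)/C=C/c4ccc(F)cc4)cc3)c2cc1OC`, carries a different core; how the core of compound 3 differs from the core of compound 1 is not broken down here. For compound 3 this assay likewise reports only a limit, > 100000 nM.

Going by the values given here, compound 4, `COc1cc2ncnc(Nc3ccc(CS(=O)(=O)/C=C/c4ccc(Br)cc4)cc3)c2cc1OC`, is not yet measured; it differs from compound 3 by bromo in place of fluoro on an aromatic carbon, the same change as the one made from compound 1 to compound 2, at a place described in the same words. Since compound 3 already sits at the limit of this assay, and the earlier step went upward to that same limit, compound 4 is expected to give a limit as well, with the expected step being a step that the limit leaves unreadable from compound 3 to compound 4. The estimated value for compound 4 is 200000 nM, expected between 100000 nM and 1000000 nM.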

Compound 4, concentration for 50% growth inhibition: 8000 nM
Compound 4: middle estimate off by 25-fold (1.40 log units), on the high side; the measured number lies below the stated range.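

In this assay bromo in place of fluoro gives an at least 12-fold lower number from compound 3 to compound 4 (1.09 log units; beyond the scatter) and thus does not carry from the core of compound 1 to the core of compound 3 with the same direction: the same change on two cores in this assay, an at least 7.6-fold higher number (0.88 log units; beyond the scatter) from compound 1 to compound 2 and an at least 12-fold lower number (1.09 log units; beyond the scatter) from compound 3 to compound 4, at least 96-fold (1.98 log units) apart, beyond the scatter of two such steps. Each of the two steps has one end at a limit of the assay, compound 2 in one pair and compound 3 in the other, so both sizes and the gap between them are bounds and not exact sizes: the limit of > 100000 nM in this assay, at which 2 of the 4 values shown sit. The two pairs do not show which part of the core goes with the reversal, and two cores give no rule for a third.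

Open, from the compounds shown here alone, is how chloro or methoxy at the same place on the phenyl ring would behave on each of the two cores, and whether either would follow the fluoro-to-bromo direction seen on that core. Also open, going by these compounds, is whether a core with a single methoxy group would side with compound 1 and compound 2 or with compound 3 and compound 4.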